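The source may report more compounds than this note shows. Statements on the series, on what has been measured and on what is new or still open speak of the compounds shown alone.

In a functional assay on CWR22R cells (Homo sapiens) for antiproliferative activity, read by propidium iodide staining, with a stated time of 96 h (a higher number here means a weaker inhibitor, a lower number a stronger inhibitor), two compounds sharing one core have been measured so far. Compound 1 `CC(O)(CSc1ccc(F)cc1)C(=O)Nc1ccc(S(F)(F)(F)(F)F)cc1` gives 13500 nM as its half-maximal inhibitory concentration, and compound 2 `CC(O)(CSc1cccc(C(F)(F)F)c1)C(=O)Nc1ccc(S(F)(F)(F)(F)F)cc1` gives 23400 nM on the same read-out. Compound 2 therefore stands level with compound 1, since the step between them is a 1.7-fold higher number from compound 1 to compound 2 (0.24 log units; within the scatter) and involves only the group on a sulfur.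

The next structure, compound 3 `CC(O)(CSc1ccc(C(F)(F)F)cn1)C(=O)Nc1ccc(S(F)(F)(F)(F)F)cc1`, differs from compound 2 at that same place. Here 5-(trifluoromethyl)pyridin-2-yl takes the place of 3-(trifluoromethyl)phenyl on a sulfur (5-(trifluoromethyl)pyridin-2-yl in place of 3-(trifluoromethyl)phenyl on a sulfur).

Going by the values given here, only one measured step bears on this change, namely a 1.7-fold higher number from compound 1 to compound 2 (0.24 log units; within the scatter) at the same sulfur. Among the compounds with values here, no measured compound yet carries a ring with a hetero atom there, so this single step is a thin guide. No step beyond the scatter, in either direction, is expected in this assay for this change, though the range must stay wide. The expected step is a 1.3-fold lower number from compound 2 to compound 3 (0.11 log units; within the scatter) and remains only an estimate. For compound 3 the estimated value is 18000 nM with an expected range from 8000 nM to 40000 nM in this measurement.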

Compound 3, half-maximal inhibitory concentration: 20000 nM
Compound 3: the middle estimate sits 1.1-fold (0.05 log units) below what was measured; the measured number falls inside the stated range.
By their numbers in this assay, from the lowest: compounds 1, 3 and 2 (each within the scatter of the next).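

Going by these compounds alone, compound 3 is the first here with a hetero atom in the ring on the sulfur, and that ring also brings a hydrogen-bond acceptor that the earlier rings lack. In this assay the step reads a 1.2-fold lower number from compound 2 to compound 3 (0.07 log units; within the scatter) and, against the other earlier compound, a 1.5-fold higher number from compound 1 to compound 3 (0.17 log units; within the scatter) so this swap, like the earlier one at the same sulfur, gives no difference that can be told apart from the ordinary spread of repeated measurements, and the position has so far tolerated a fluorine-bearing ring, a ring of carbon only with trifluoromethyl, and a ring with nitrogen and trifluoromethyl alike. Nothing available here accounts for how little the number differs across these three groups.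

As far as these compounds go, all three compounds keep an aromatic ring on the sulfur, so it remains open whether an amine or a carboxylic acid on that ring, or a longer saturated chain in place of the ring, would give a step beyond the scatter. The rest of the shared core is the same throughout, so these compounds also say nothing about what a change elsewhere in the molecule would do.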